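Swapping a pyrrolidinone substituent: expected cytotoxicity of compound 4

This account rests on a few compounds, and the source may have more. Where it says the series, first, only, none or still open, it means among the compounds named here.

Measured so far:
compound 1 `C[C@H]1Cn2ncc(N3CC(c4ccccc4)CC3=O)c2CN1S(=O)(=O)Nc1cc(F)c(F)c(F)c1` — > 2000 nM
compound 2 `CC1(C)CC(=O)N(c2cnn3c2CN(C(=O)Nc2cc(F)c(F)c(F)c2)C(C2CC2)C3)C1` — 115000 nM
compound 3 `CC1(C)CN(C(=O)Nc2cc(F)c(F)c(F)c2)Cc2c(N3CC(C#N)CC3=O)cnn21` — > 200000 nM

Of the compounds shown here, three have been tested in a toxicity assay on HepG2 2.2.15 cells (Homo sapiens) for cytotoxicity, read by CellTiter-Glo; on this read-out higher numbers stand for lower toxicity in this test and lower numbers for higher toxicity in this test. Compound 1 gives > 2000 nM, which is a limit of the assay rather than a number (the limit of > 2000 nM in this assay, at which 1 of the 3 values shown sits). Compound 3 likewise gives > 200000 nM, again a limit (the limit of > 200000 nM in this assay, at which 1 of the 3 values shown sits). Among the measured compounds shown here, compound 2 gives 115000 nM, the only actual number among the three.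

Compound 4 `O=C1CC(c2nccs2)CN1c1cnn2c1CN(C(=O)Nc1cc(F)c(F)c(F)c1)C(C1CC1)C2` differs from compound 2 by 2-oxo-4-(1,3-thiazol-2-yl)pyrrolidin-1-yl in place of 4,4-dimethyl-2-oxopyrrolidin-1-yl on an aromatic carbon. For the measured compounds named here, no measured pair differing in one place exists here, so no step size can be read from the data. The step from compound 2 to compound 4 is expected to be a 1.2-fold lower number from compound 2 to compound 4 (0.06 log units; within the scatter), that is, nothing beyond the scatter. Compound 4 is accordingly estimated at 100000 nM, within 40000 nM to 200000 nM.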

Compound 4, half-maximal cytotoxic concentration: 115000 nM
Estimate against measurement, compound 4: 1.2-fold (0.06 log units) below, and the stated range covers the measured number.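

In this assay, among the compounds shown here, there is no change at the digits printed from compound 2 to compound 4 (within the scatter) when 2-oxo-4-(1,3-thiazol-2-yl)pyrrolidin-1-yl takes the place of 4,4-dimethyl-2-oxopyrrolidin-1-yl on an aromatic carbon, and this is the first readable step at this position. It shows that a pyrrolidinone carrying a five-membered aromatic ring is tolerated here in this read-out as well as the dimethyl group is. Nothing measured here accounts for this outcome.

From the compounds shown here alone, whether an amine or a carboxylic acid on the pyrrolidinone would leave the read-out equally unmoved remains open. For the compounds shown here, compound 1 and compound 3 differ from these two in more than one place, so no step to them can be read.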